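Changing the para-substituent on the aryl ring of a thiophene sulfonylcarbamate

This account rests on a few compounds, and the source may have more. Where it says the series, first, only, none or still open, it means among the compounds named here.

The measured compounds:
compound 1, `CCCCOC(=O)NS(=O)(=O)c1sc(CC(C)C)cc1-c1ccc(CN2CCN(C)C2=O)cc1`, 16.5 nM in an assay on membranes from uterus for displacement of a labelled ligand from Angiotensin type II receptor (Sus scrofa), with a stated time of 1.5 h; a lower number here means a stronger inhibitor, a higher number a weaker inhibitor
compound 2, `CCCCOC(=O)NS(=O)(=O)c1sc(CC(C)C)cc1-c1ccc(CN2C(=O)CCC2=O)cc1`, > 10000 nM in this assay

The shared core of these compounds carries a substituted benzene ring, and the two measured compounds differ only in the group on that ring. Compound 1 gives 16.5 nM in this assay. For compound 2 the assay reports only a limit, > 10000 nM, so no number is known for it. Going by the values given here, the step of an at least 600-fold higher number from compound 1 to compound 2 (2.78 log units; beyond the scatter) is the only measured step and it is large, showing that the group on this aromatic carbon matters greatly; it rests on (the limit of > 10000 nM in this assay, at which 1 of the 2 values shown sits).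

Compound 3, `CCCCOC(=O)NS(=O)(=O)c1sc(CC(C)C)cc1-c1ccc(C(=O)c2cccs2)cc1`, has not yet been measured. It differs from compound 2 by (thiophen-2-yl)carbonyl in place of (2,5-dioxopyrrolidin-1-yl)methyl on an aromatic carbon. Among the compounds with values here, no measured step covers this particular exchange, and since compound 2 stands only at a limit, the size of the step from compound 2 to compound 3 cannot be fixed from the data. Within the data shown here, the one measured step at this position was large, so a large movement away from the limit, toward a stronger inhibitor, is expected: an at least 250-fold lower number from compound 2 to compound 3 (2.39 log units; beyond the scatter). Compound 3 is estimated at 40 nM, within 5 nM to 400 nM.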

Compound 3, inhibition constant: 18.8 nM
Compound 3: middle estimate off by 2.1-fold (0.33 log units), on the high side, and the stated range covers the measured number.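

In this assay, the exchange of (2,5-dioxopyrrolidin-1-yl)methyl for (thiophen-2-yl)carbonyl gives an at least 530-fold lower number from compound 2 to compound 3 (2.72 log units; beyond the scatter), a second large step at this aromatic carbon, and its size is only a bound: the limit of > 10000 nM in this assay, at which 1 of the 3 values shown sits.

The other comparison, a 1.1-fold higher number from compound 1 to compound 3 (0.06 log units; within the scatter), shows that (thiophen-2-yl)carbonyl and (3-methyl-2-oxoimidazolidin-1-yl)methyl cannot be told apart in this assay. This position therefore accepts two quite different groups with no reading of a difference between them, one joined through a carbonyl and the other through a saturated chain carbon, and among the three compounds only compound 2, with its (2,5-dioxopyrrolidin-1-yl)methyl group, goes against this.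

Compound 3 changes the ring and its link to the benzene ring at once, so the compounds shown do not separate the part each plays. On these data alone, whether (thiophen-2-yl)methyl, a benzoyl group or a furan-2-ylcarbonyl group would keep the number in the same range at this position stays open, as does the effect of a simple amine or a carboxylic acid there.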